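A few compounds are considered here, and "the series" means these few. Any claim that something is new, unique, unknown or untested is made for them only; others in the source may bear on it.

Measured compounds
compound 1 `CCSCc1c(C)nc2c(OCc3ccccc3)cccn12` — 36%
compound 2 `Cc1nc2c(OCc3ccccc3)cccn2c1Cl` — 93%

In a functional assay on the whole organism with Rattus norvegicus as the target, with a stated time of 4 h, at a dose of 40 mg/kg by the intraperitoneal route (on this read-out higher numbers stand for more inhibition at the one dose given (going by the name of the read-out) and lower numbers for less inhibition), compound 2 gives 93%, the highest of the two numbers recorded. The nearest is compound 1, which in this assay gives 36%, a lower number, with the gap beyond the scatter.

Compound 3 `COC(=O)Cc1c(C)nc2c(OCc3ccccc3)cccn12` is not yet measured. It differs from compound 2 in one place: (methoxycarbonyl)methyl in place of chloro on an aromatic carbon.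

Among the compounds with values here, one measured step bears on this position: a number 57 percentage points higher from compound 1 to compound 2 (beyond the scatter). That step shows that exchanging a carbon-linked chain for chloro at this aromatic carbon went with a large rise. The present change goes the other way, replacing chloro with a carbon-linked chain, though the chain itself is a different one, so the step to compound 1 is a guide to direction rather than to size. Two compounds give no pattern beyond this.

On that basis a drop beyond the scatter is expected in this assay, of roughly a number 43 percentage points lower from compound 2 to compound 3 (beyond the scatter). Compound 3 is therefore estimated at 50%, with a range from 20% to 85%.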

Compound 3, a percentage reported as inhibition, in the whole organism at one dose (the size of the read-out at that dose, not a potency): 23%
Beside the measured number, compound 3's estimate is 27 percentage points above it; the measured number falls inside the stated range.
By their numbers in this assay, from the lowest: compound 3; then compound 1; then compound 2.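

In this assay, (methoxycarbonyl)methyl in place of chloro on the aromatic carbon gives a number 70 percentage points lower from compound 2 to compound 3 (beyond the scatter), so a fall on leaving chloro now holds for a second carbon-linked chain and is no longer tied to (ethylsulfanyl)methyl alone. Exchanging one chain for the other at the saturated chain carbon gives a number 13 percentage points lower from compound 1 to compound 3 (beyond the scatter). Within the data shown here, this step is beyond the scatter but modest, and in this set of three compounds the larger difference lies between chloro and either chain, with no compound going against that reading. No measurement at hand gives a reason for either step.

The compounds shown leave open whether the high number belongs to chloro itself or would also appear with bromo, fluoro or a plain hydrogen on the same aromatic carbon. They also leave open whether a chain ending in a carboxylic acid or an amine, or a longer chain, would stay as low as the two chains here, and how any of these three compounds would read at another dose or time.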